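Phenyl in place of 2-cyclohexylethyl on a carbonyl carbon

The source may report more compounds than this note shows. Statements on the series, on what has been measured and on what is new or still open speak of the compounds shown alone.

In an ADME assay on HepG2 2.2.15 cells (Homo sapiens) for cytotoxicity (on this read-out lower numbers stand for higher toxicity in this test and higher numbers for lower toxicity in this test), compound 1 `O=c1[nH]c2ccc(Cl)cc2c(-c2ccccc2Cl)c1CCO` gives 380000 nM, compound 2 `O=C(OCCc1c(-c2ccccc2Cl)c2cc(Cl)ccc2[nH]c1=O)C1CCCCC1` gives 38000 nM and compound 3 `O=C(CCC1CCCCC1)OCCc1c(-c2ccccc2Cl)c2cc(Cl)ccc2[nH]c1=O` gives 160000 nM. That puts compound 3 second highest of the three numbers. Compound 4 `O=C(OCCc1c(-c2ccccc2Cl)c2cc(Cl)ccc2[nH]c1=O)c1ccccc1` has not been measured yet. Its difference from compound 3 is phenyl in place of 2-cyclohexylethyl on a carbonyl carbon.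

Two measured steps show what adding a group to the oxygen of compound 1 did: a 10-fold lower number from compound 1 to compound 2 (1.00 log units; beyond the scatter) and a 2.4-fold lower number from compound 1 to compound 3 (0.38 log units; beyond the scatter). The closest guide is a 4.2-fold higher number from compound 2 to compound 3 (0.62 log units; beyond the scatter), where 2-cyclohexylethyl replaced cyclohexyl on a carbonyl carbon. Within the data shown here, compound 4 resembles compound 2 in carrying a six-membered ring on that carbon, although its ring is aromatic and no measured compound has such a group there. A modest move back towards lower numbers therefore seems likely, with the expected change being a 2.7-fold lower number from compound 3 to compound 4 (0.43 log units; beyond the scatter). For compound 4 the estimated value is 60000 nM, with an expected range from 20000 nM to 180000 nM.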

Compound 4, half-maximal cytotoxic concentration: 43000 nM
For compound 4 the middle estimate is 1.4-fold (0.14 log units) above the measured one, within the range that was stated.
By their numbers in this assay, from the lowest: compounds 2 and 4 (each within the scatter of the next); then compound 3; then compound 1.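

In this assay, whether the six-membered ring on the carbonyl carbon is aromatic or not makes no difference that this test can detect, as a 1.1-fold higher number from compound 2 to compound 4 (0.05 log units; within the scatter) shows. Replacing 2-cyclohexylethyl with phenyl gives a 3.7-fold lower number from compound 3 to compound 4 (0.57 log units; beyond the scatter), and adding benzoyl to the oxygen of compound 1 gives an 8.8-fold lower number from compound 1 to compound 4 (0.95 log units; beyond the scatter), so the two esters with a ring bonded directly to the carbonyl carbon, compound 2 and compound 4, read alike, while compound 3, with its ring further out on a chain, stands closer to compound 1. No measurement here explains why these numbers fall as they do.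

Going by these compounds, it remains open whether a 2-phenylethyl group on the carbonyl carbon would give a number near that of compound 3, which would show that the chain matters more than the ring type. How a small acetyl group or an amine-bearing chain would read there is also unknown.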